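Phenyl gives way to 1-phenylethyl on the amide nitrogen

The source may report more compounds than this note shows. Statements on the series, on what has been measured and on what is new or still open speak of the compounds shown alone.

In a functional assay on MCF7 cells (Homo sapiens) for antiproliferative activity, read by MTT assay, with a stated time of 24 h (a higher number here means a weaker inhibitor, a lower number a stronger inhibitor), compound 1 `CCCCc1oc2ccccc2c1C(=O)c1ccc(OCC(N)=O)cc1` gives > 50000 nM as a limit of the assay, not a number. Going by the values given here, compound 2 `CCCCc1oc2ccccc2c1C(=O)c1ccc(OCC(=O)Nc2ccccc2)cc1` gives 33600 nM here, the only true number so far. Among the compounds with values here, compound 3 `CCCCc1oc2ccccc2c1C(=O)c1ccc(OCC(=O)N[C@H](C)c2ccccc2)cc1` has 1-phenylethyl in place of phenyl on an amide-type nitrogen as its single change. Within the data shown here, the one measured step at this nitrogen is an at least 1.4-fold lower number from compound 1 to compound 2 (0.17 log units; that floor lies within the scatter) with phenyl in place of hydrogen, so no step beyond the scatter is expected in this assay for the new swap. The expected change is a 1.1-fold lower number from compound 2 to compound 3 (0.05 log units; within the scatter) and stays within the scatter. For compound 3 the estimated value is 30000 nM with a range from 14000 nM to 50000 nM overall.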

Compound 3, half-maximal inhibitory concentration: 14100 nM
The estimate for compound 3 lay 2.1-fold (0.33 log units) above the measured number; the range from low to high includes it.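

Going by these compounds alone, at this amide nitrogen, 1-phenylethyl in place of phenyl gives a 2.4-fold lower number from compound 2 to compound 3 (0.38 log units; beyond the scatter) in this assay, the first step here to clear the scatter. Against the unsubstituted amide, 1-phenylethyl gives an at least 3.5-fold lower number from compound 1 to compound 3 (0.54 log units; beyond the scatter), so this step too lies beyond the scatter. That size is only a floor, because compound 1 stands at a limit of the assay: the limit of > 50000 nM in this assay, at which 1 of the 3 values shown sits.

The compounds shown leave open whether the mirror-image form of compound 3 gives a similar number. They also leave open how benzyl or 2-phenylethyl on this nitrogen would read.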